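This account rests on a few compounds, and the source may have more. Where it says the series, first, only, none or still open, it means among the compounds named here.

The measured compounds in a functional assay on MC-38 cells (Mus musculus) for antiproliferative activity, read by colorimetric assay and MTT assay; a higher number here means a weaker inhibitor, a lower number a stronger inhibitor:
compound 1, `O=S(=O)(Nc1cccc2cc[nH]c12)c1ccc(Cl)cc1`, 7 ug/mL;
compound 2, `O=S(=O)(Nc1ccc(Cl)c2cc[nH]c12)c1ccc(Cl)cc1`, 0.66 ug/mL;
compound 3, `O=[N+]([O-])c1ccc(S(=O)(=O)Nc2cccc3cc[nH]c23)cc1`, 7.2 ug/mL.

Compound 1 and compound 2 share a core and differ by chloro in place of hydrogen on an aromatic carbon, a change that gave an 11-fold lower number from compound 1 to compound 2 (1.03 log units; beyond the scatter). Compound 3 differs from compound 1 by nitro in place of chloro on an aromatic carbon, and this gave a 1.0-fold higher number from compound 1 to compound 3 (0.01 log units; within the scatter). Compound 4, `O=[N+]([O-])c1ccc(S(=O)(=O)Nc2cc(Cl)cc3cc[nH]c23)cc1`, has not yet been measured; it differs from compound 3 by chloro in place of hydrogen on an aromatic carbon. This is the same kind of change as that from compound 1 to compound 2, but not the same: in compound 2 the chloro sits ortho to a fused ring, meta to a fused ring and para to a large group, whereas in compound 4 it sits meta to a fused ring, meta to a large group and para to a fused ring. The change occurs twice among these compounds, once measured. A lower number is expected for compound 4 because the step of an 11-fold lower number from compound 1 to compound 2 (1.03 log units; beyond the scatter) was large. The place differs, however, and the step expected from compound 3 to compound 4 is smaller, a 2.9-fold lower number from compound 3 to compound 4 (0.46 log units; beyond the scatter). Compound 4 is therefore estimated at 2.5 ug/mL, between 0.8 ug/mL and 7.2 ug/mL.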

Compound 4, half-maximal inhibitory concentration: 13 ug/mL
The estimate for compound 4 lay 5.2-fold (0.72 log units) below the measured number; measured number outside the range, above it.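

In this assay, chloro in place of hydrogen on an aromatic carbon gave a 1.8-fold higher number from compound 3 to compound 4 (0.26 log units; within the scatter), so the new step stays within the scatter and the large step seen on the core of compound 1 did not carry over to compound 4. The two steps of this one change disagree: the same change on two cores in this assay, an 11-fold lower number (1.03 log units; beyond the scatter) from compound 1 to compound 2 and a 1.8-fold higher number (0.26 log units; within the scatter) from compound 3 to compound 4, 19-fold (1.28 log units) apart, beyond the scatter of two such steps. This shows that the effect of the change cannot be assumed to transfer within this series, but it does not show why, as the two pairs differ at once in the core, with chloro in compound 1 and nitro in compound 3, and in where the new chloro sits, and these two differences cannot be separated here.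

The compounds shown leave open whether chloro placed as in compound 2 would give a large step on the core of compound 3, and whether chloro placed as in compound 4 would do so on the core of compound 1. They also leave open how an amine or a carboxylic acid would behave in place of the nitro or the chloro.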